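Urea in place of pyrrolidine amide on the biaryl series

The source may report more compounds than this note shows. Statements on the series, on what has been measured and on what is new or still open speak of the compounds shown alone.

Measured compounds:
compound 1 `CCOc1ccc(-c2cccc(S(=O)(=O)N(C)C)c2)cc1` 110000 nM
compound 2 `CCOc1ccc(-c2cccc(C)c2)cc1` 70000 nM
compound 3 `CCOc1ccc(-c2cccc(C(=O)N3CCCC3)c2)cc1` 160000 nM

All three compounds share one core and differ only in the group on the aromatic carbon. In an assay on COS-7 cells for inhibition of patatin-like phospholipase domain-containing protein 2 (Mus musculus) (on this read-out higher numbers stand for weaker inhibition and lower numbers for stronger inhibition), compound 3 gives the highest of the three numbers; its nearest neighbour is compound 1, and the step of a 1.5-fold higher number from compound 1 to compound 3 (0.16 log units; within the scatter) lies within the scatter, while the step of a 2.3-fold higher number from compound 2 to compound 3 (0.36 log units; beyond the scatter) is modest but beyond it. Compound 4 `CCOc1ccc(-c2cccc(NC(=O)N(C)C)c2)cc1` follows from compound 3 by a single change: (dimethylcarbamoyl)amino in place of (pyrrolidin-1-yl)carbonyl on an aromatic carbon. Going by the values given here, none of the measured steps swaps the pyrrolidinylcarbonyl for a group carrying a hydrogen-bond donor, so the two steps that end at compound 3 are the only guide. They show that replacing the group on this carbon moves this assay by small amounts only, and in both directions. For compound 4 the account therefore expects a step of a 1.5-fold lower number from compound 3 to compound 4 (0.16 log units; within the scatter), which is within the scatter and carries no reliable direction. Compound 4 is estimated at 110000 nM, with a range of 45000 nM to 270000 nM, in this assay.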

Compound 4, half-maximal inhibitory concentration: 70000 nM
Estimate against measurement, compound 4: 1.6-fold (0.20 log units) above; the measured number falls inside the stated range.
By their numbers in this assay, from the lowest: compounds 2, 4, 1 and 3 (each within the scatter of the next, the first and the last beyond it).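

In this assay, going by these compounds alone, the step of a 2.3-fold lower number from compound 3 to compound 4 (0.36 log units; beyond the scatter) is modest but beyond the scatter, so exchanging (pyrrolidin-1-yl)carbonyl for (dimethylcarbamoyl)amino, the only group of the four that carries a hydrogen-bond donor, does register at this aromatic carbon. The other two steps, no change at the digits printed from compound 2 to compound 4 (within the scatter) and a 1.6-fold lower number from compound 1 to compound 4 (0.20 log units; within the scatter), stay within the scatter, so the donor-bearing group does not set compound 4 apart from the methyl of compound 2 or the dimethylsulfamoyl of compound 1, neither of which carries a donor. Nothing available here accounts for the step from compound 3 to compound 4 in terms of any property of the two groups.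

That step loses the five-membered non-aromatic ring and gains the hydrogen-bond donor at once, and a dimethylcarbamoyl group attached directly to the aromatic carbon would be needed to tell those two changes apart. The compounds shown also leave open how this assay would respond at the same carbon to a carboxylic acid, a primary amine or a longer alkyl chain.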